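Fluoro in Place of Methoxy: Cytotoxicity Outlook for Compound 4

The source may report more compounds than this note shows. Statements on the series, on what has been measured and on what is new or still open speak of the compounds shown alone.

Measured so far:
- Compound 1 `COc1ccc(S(=O)(=O)N2CCC3(CC2)OOC2(CCCCC2)OO3)cc1` in a functional assay on Huh-7 cells (Homo sapiens) for cytotoxicity, read by MTT assay, with a stated time of 72 h (on this read-out lower numbers stand for higher toxicity in this test and higher numbers for lower toxicity in this test), gives > 100 ug/mL, which is a limit of the assay and not a number.
- Compound 2 `COc1ccc(S(=O)(=O)N2CCC3(CC2)OOC2(CCCCCC2)OO3)cc1` in this assay gives > 100 ug/mL, again a limit of the assay rather than a number.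
- Compound 3 `O=S(=O)(c1ccc(F)cc1)N1CCC2(CC1)OOC1(CCCCC1)OO2` in this assay gives > 100 ug/mL, also a limit of the assay.

Compound 3 differs from compound 1 by fluoro in place of methoxy on an aromatic carbon. The step that the two limits leave unreadable from compound 1 to compound 3, since all three values sit at the limit of > 100 ug/mL in this assay, at which 3 of the 3 values shown sit. Compound 2 and compound 1 differ in their cores, and that difference is not broken down here.

Compound 4 `O=S(=O)(c1ccc(F)cc1)N1CCC2(CC1)OOC1(CCCCCC1)OO2` has not yet been measured in this assay. It differs from compound 2 by fluoro in place of methoxy on an aromatic carbon, the same change as from compound 1 to compound 3, made at the same place. Because compound 1, compound 2 and compound 3 all rest at the limit of > 100 ug/mL in this assay, at which 3 of the 3 values shown sit, compound 4 is expected to do likewise. Compound 4 is estimated at 150 ug/mL, an expected step that the limit leaves unreadable from compound 2 to compound 4.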

Compound 4, half-maximal cytotoxic concentration: > 100 ug/mL
Compound 4: no number, only a limit; the forecaster's own chance of this, stated with the estimate: 85%; the middle value does not contradict the limit.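

Going by these compounds alone, compound 2 and compound 4 both give only a limit of the assay, so no step between them can be read: the limit of > 100 ug/mL in this assay, at which 4 of the 4 values shown sit.

The compounds shown leave open whether methoxy and fluoro differ in toxicity, and at what concentration any of the four would harm these cells.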